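The compounds below may be only part of what the source reports. "The series", "measured", "known", "first", "only" and "open" are said of these compounds alone.

In a functional assay on MKN-45 cells (Homo sapiens) for antiproliferative activity, read by CellTiter-Glo, with a stated time of 3 days (a higher number here means a weaker inhibitor, a lower number a stronger inhibitor), compound 1 (`CC(Oc1c(N)ncc2c(-c3cnn(C4CCNCC4)c3)coc12)c1c(Br)ccc(F)c1Cl`) gives 510 nM and compound 2 (`CCC(Oc1c(N)ncc2c(-c3cnn(C4CCNCC4)c3)coc12)c1c(Cl)ccc(F)c1Cl`) gives 3600 nM as its measured value. Compound 2 therefore holds the higher of the two numbers and is the weaker inhibitor of the pair, and the gap between them lies beyond the usual scatter. The two compounds differ in more than one place, so that gap cannot be pinned on any single change. Compound 3 (`C#CCC(Oc1c(N)ncc2c(-c3cnn(C4CCNCC4)c3)coc12)c1c(Cl)ccc(F)c1Cl`) is compound 2 with ethynyl in place of methyl on a saturated chain carbon, two bonds along the chain from an aromatic carbon and an oxygen on an aromatic ring. Cut one bond further out, the same difference reads ethyl to propargyl. Among the measured compounds shown here, no measured step isolates this change, so the expectation is only loosely grounded. A modest step toward a higher number in this assay is expected, and it may not clear the scatter by much. The expected change is a 1.4-fold higher number from compound 2 to compound 3 (0.14 log units; within the scatter) on this reasoning. Compound 3 is estimated at 5000 nM with an expected range of 1500 nM to 15000 nM for its measurement.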

Compound 3, half-maximal inhibitory concentration: 360 nM
Compound 3: middle estimate off by 14-fold (1.14 log units), on the high side; the whole stated range lies above it.
By their numbers in this assay, from the lowest: compounds 3 and 1 (each within the scatter of the next); then compound 2.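

In this assay, the step of a 10-fold lower number from compound 2 to compound 3 (1.00 log units; beyond the scatter) is the first measured change in a single place among these compounds. It shows that the saturated chain carbon, two bonds along the chain from an aromatic carbon and an oxygen on an aromatic ring, is sensitive to what it carries: with the rest of compound 2 unchanged, going from ethyl to propargyl moves the number well beyond the scatter, toward the stronger end. Nothing measured here explains the size of this step, which rests on this one pair alone.

The compounds shown leave open whether the triple bond itself or simply the longer chain goes with the lower number, a question that propyl or allyl on the same carbon would help to separate. They also leave open how far this carbon accepts larger or different groups, such as a phenyl on the far end of the propargyl chain, a nitrile or a primary amine, and whether the step would hold elsewhere on the shared core.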